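From 3-bromophenyl to 4-bromophenyl on the shared core

This account rests on a few compounds, and the source may have more. Where it says the series, first, only, none or still open, it means among the compounds named here.

Compound 1 (`COc1cccc(/C=C2\CCC/C(=C\c3ccc(Cl)cc3)C2=O)c1OC`) gives 11100 nM
Compound 2 (`COc1cccc(/C=C2\CCC/C(=C\c3ccccc3Br)C2=O)c1OC`) gives 10800 nM
Compound 3 (`COc1cccc(/C=C2\CCC/C(=C\c3cccc(Br)c3)C2=O)c1OC`) gives 12200 nM

These three values come from a functional assay on HT-1080 cells (Homo sapiens) for cytotoxicity, read by MTT assay, with a stated time of 72 h (on this read-out lower numbers stand for stronger inhibition and higher numbers for weaker inhibition), and lie within the scatter of one another, so compound 3 holds no distinct rank among them. The next compound, compound 4 (`COc1cccc(/C=C2\CCC/C(=C\c3ccc(Br)cc3)C2=O)c1OC`), has not yet been measured. It differs from compound 3 by 4-bromophenyl in place of 3-bromophenyl on a double-bonded chain carbon bound to a double-bonded ring carbon.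

Going by the values given here, three measured steps bear on this change. Compound 1 is the closest guide since it already carries a 4-substituted phenyl, 4-chlorophenyl, and the data show a 1.1-fold higher number from compound 1 to compound 3 (0.04 log units; within the scatter) when 3-bromophenyl replaces that group. The exchange of 2-bromophenyl for 3-bromophenyl shows a 1.1-fold higher number from compound 2 to compound 3 (0.05 log units; within the scatter) and the remaining pair shows a 1.0-fold lower number from compound 1 to compound 2 (0.01 log units; within the scatter) on the same read-out. Among the compounds with values here, none of these steps leaves the scatter, although no measured pair holds exactly this exchange.

The estimate is a 1.1-fold lower number from compound 3 to compound 4 (0.03 log units; within the scatter) and so no step beyond the scatter is expected in this assay for this change. Compound 4 is expected to give about 11300 nM (estimated range 7000 nM to 18000 nM).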

Compound 4, half-maximal inhibitory concentration: 13700 nM
Compound 4: the middle estimate sits 1.2-fold (0.08 log units) below what was measured, within the range that was stated.
By their numbers in this assay, from the lowest: compounds 2, 1, 3 and 4 (each within the scatter of the next).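

In this assay the exchange of 3-bromophenyl for 4-bromophenyl on a double-bonded chain carbon bound to a double-bonded ring carbon gives a 1.1-fold higher number from compound 3 to compound 4 (0.05 log units; within the scatter) and the exchange of 2-bromophenyl for 4-bromophenyl gives a 1.3-fold higher number from compound 2 to compound 4 (0.10 log units; within the scatter) so all three bromophenyl groups now stand measured at this place without any one separating from the others. Going by these compounds alone, the result also adds the first exchange of the halogen alone on an otherwise unchanged group, bromo in place of chloro on an aromatic carbon, which gives a 1.2-fold higher number from compound 1 to compound 4 (0.09 log units; within the scatter) and so also stays inside the scatter on this read-out. No measurement is available that would account for how closely these four compounds sit together.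

On these data alone, all four compounds carry a chloro or bromo group on the phenyl at this place, so it remains open whether an amine or a carboxylic acid there would give a step beyond the scatter. The rest of the shared core is the same in all four compounds, which leaves open what a change elsewhere on it would do in this assay.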